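Changing the carbonyl substituent from compound 2 to compound 3

The source may hold more compounds than are shown below. What is called first, only, known or untested is meant among the compounds shown, and "the series" means these compounds.

In an ADME assay on CCRF-CEM cells (Homo sapiens) for cytotoxicity, with a stated time of 4 days (a higher number here means that more compound is tolerated, a lower number that less compound is tolerated), compound 1 (`Cc1cn([C@@H]2O[C@H](CO[Si](C)(C)C(C)(C)C)[C@@]3(OS(=O)(=O)C=C3N)[C@H]2O[Si](C)(C)C(C)(C)C)c(=O)n(C(=O)c2ccccc2)c1=O`) gives 54000 nM. Compound 2 (`COC(=O)n1c(=O)c(C)cn([C@@H]2O[C@H](CO[Si](C)(C)C(C)(C)C)[C@@]3(OS(=O)(=O)C=C3N)[C@H]2O[Si](C)(C)C(C)(C)C)c1=O`) gives > 100000 nM, which is a limit of the assay and not a number. Compound 3 (`CSC(=O)CCCC(=O)n1c(=O)c(C)cn([C@@H]2O[C@H](CO[Si](C)(C)C(C)(C)C)[C@@]3(OS(=O)(=O)C=C3N)[C@H]2O[Si](C)(C)C(C)(C)C)c1=O`) carries 3-((methylsulfanyl)carbonyl)propyl in place of methoxy on a carbonyl carbon. Going by the values given here, the one measured step at this carbonyl carbon, methoxy in place of phenyl, is an at least 1.8-fold higher number from compound 1 to compound 2 (0.26 log units; that floor lies within the scatter), and it is a weak guide to size. The expected change is an at least 1.4-fold lower number from compound 2 to compound 3 (0.15 log units; that floor lies within the scatter), a modest move towards a lower number. For compound 3 the estimated value is 70000 nM, with an expected range of 30000 nM to 100000 nM.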

Compound 3, half-maximal cytotoxic concentration: 9900 nM
Compound 3: middle estimate off by 7.1-fold (0.85 log units), on the high side, and the stated range ends above it.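

At this carbonyl carbon, 3-((methylsulfanyl)carbonyl)propyl in this assay gives an at least 10-fold lower number from compound 2 to compound 3 (1.00 log units; beyond the scatter) and a 5.5-fold lower number from compound 1 to compound 3 (0.74 log units; beyond the scatter), leaving compound 3 the least tolerated of the three. The earlier step at this place had only a floor within the scatter; this change shows that the place can move the number beyond it. Compound 2 stands at a limit, so its step is a floor only: the limit of > 100000 nM in this assay, at which 1 of the 3 values shown sits.

From the compounds shown here alone, whether the chain or its (methylsulfanyl)carbonyl end carries the drop stays open. A plain alkyl chain, or a carboxylic acid at the chain end, would separate the two.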